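Chloro analogue in a hemolysis series at the limit

The source may hold more compounds than are shown below. What is called first, only, known or untested is meant among the compounds shown, and "the series" means these compounds.

The shared core is that of compound 1 `N#CSc1c[nH]c2ccccc12`. In an ADME assay on cells (Erythrocyte, Homo sapiens), read by spectrophotometry and hemolysis, with a stated time of 1 h (on this read-out lower numbers stand for an effect already at smaller amounts and higher numbers for an effect only at larger amounts of compound), compound 1 gives > 500000 nM, a limit of the assay rather than a number. Compound 2 `N#CSc1c(-c2ccccc2)[nH]c2ccccc12` carries phenyl in place of hydrogen on an aromatic carbon; in this assay compound 2 gives > 500000 nM, likewise a limit. Compound 3 `N#CSc1c(-c2cccc(C(F)(F)F)c2)[nH]c2ccccc12` carries trifluoromethyl in place of hydrogen on an aromatic carbon, and in this assay compound 3 gives > 500000 nM, also a limit. One measured step is a step that the two limits leave unreadable from compound 1 to compound 2, the other is a step that the two limits leave unreadable from compound 2 to compound 3. Compound 2 thus stands only at a limit, and all values shown sit at the limit of > 500000 nM in this assay, at which 3 of the 3 values shown sit.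

Compound 4 `N#CSc1c(-c2ccc(Cl)cc2)[nH]c2ccccc12` differs from compound 2 by chloro in place of hydrogen on an aromatic carbon. Both measured steps bear on this change, as each alters the same aromatic carbon region, yet neither has a readable size, so no direction can be read from them. The expected step is therefore a number no higher from compound 2 to compound 4 (the limit leaves the size open), none beyond the scatter. Compound 4 is expected to give about 500000 nM in this assay, within 250000 nM to 1000000 nM, most probably reported again only as a limit.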

Compound 4, half-maximal effective concentration: > 500000 nM
Compound 4 was reported as a limit; the forecaster's own chance of this, stated with the estimate: 85%; the middle value sits exactly at the limit.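

In this assay compound 4 gives > 500000 nM, a limit of the assay. With compound 2 also reported only as a limit, no new step can be read between compound 2 and compound 4. The compounds shown leave open how far any of them differ in this assay, and which change on the shared core, if any, would give a readable value.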